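Dichloro to difluoro on the enone aryl of the series

A few compounds are considered here, and "the series" means these few. Any claim that something is new, unique, unknown or untested is made for them only; others in the source may bear on it.

Compound 1 `COc1cc(-c2cc(/C=C/C(=O)c3ccc(N)cc3)[nH]n2)cc(OC)c1OC` gives 9980 nM in a functional assay on SNB-19 cells (Homo sapiens) for inhibition, read by sulforhodamine B assay, with a stated time of 48 h; on this read-out higher numbers stand for weaker inhibition of growth and lower numbers for stronger inhibition of growth. Compound 2 `COc1ccc(-c2cc(/C=C/C(=O)c3ccc(OC)c(OC)c3)[nH]n2)cc1` gives 5280 nM in this assay. Compound 3 `COc1cc(-c2cc(/C=C/C(=O)c3ccc(Cl)c(Cl)c3)[nH]n2)cc(OC)c1OC` reaches only a limit in this assay, > 100000 nM, so its standing is known only as a bound (the limit of > 100000 nM in this assay, at which 1 of the 3 values shown sits). Among the compounds with values here, the one step that touches it, an at least 10-fold higher number from compound 1 to compound 3 (1.00 log units; beyond the scatter), shows how far it sits from compound 1. Compound 4 `COc1cc(-c2cc(/C=C/C(=O)c3ccc(F)c(F)c3)[nH]n2)cc(OC)c1OC` differs from compound 3 by 3,4-difluorophenyl in place of 3,4-dichlorophenyl on a carbonyl carbon. Within the data shown here, no measured step pairs the two halogens, so the expectation for this assay rests on compound 3 lying at a limit: a move of an at least 2.0-fold lower number from compound 3 to compound 4 (0.30 log units; that floor lies within the scatter) toward somewhat stronger inhibition is estimated, still weak overall. Compound 4 is expected at 50000 nM, between 10000 nM and 200000 nM.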

Compound 4, concentration for total growth inhibition: > 100000 nM
Compound 4: only a limit was reported (the forecaster's own chance of this, stated with the estimate: 45%); at least 2.0-fold (0.30 log units) between middle value and limit.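

In this assay, 3,4-difluorophenyl in place of 3,4-dichlorophenyl on the carbonyl carbon gives a step that cannot be read, so the two halogens cannot be ranked. Against 4-aminophenyl, 3,4-difluorophenyl gives an at least 10-fold higher number from compound 1 to compound 4 (1.00 log units; beyond the scatter), which places both dihalogenated aryl groups on the weaker side of compound 1. Compound 3 and compound 4 therefore both rest at a limit: the limit of > 100000 nM in this assay, at which 2 of the 4 values shown sit.

Going by these compounds, whether an aryl group carrying a hydroxyl or a carboxylic acid at this carbonyl carbon gives a value short of that limit stays open. So does whether a dimethylamino group keeps the readable value of compound 1.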